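A few compounds are considered here, and "the series" means these few. Any claim that something is new, unique, unknown or untested is made for them only; others in the source may bear on it.

Two compounds share one core and differ only in the group carried on an aromatic nitrogen. Compound 1 `CCc1nc2c(-c3ccc(Cl)cc3Cl)ccnc2n1C(CCOC)C1CC1` gives 1.5 nM in an assay for binding affinity to Corticotropin releasing factor receptor (Rattus norvegicus); a higher number here means a weaker inhibitor, a lower number a stronger inhibitor. Among the measured compounds shown here, compound 2 `CCc1nc2c(-c3ccc(Cl)cc3Cl)ccnc2n1[C@H](C)C1CC1` gives 0.6 nM in this assay, the lowest of the two numbers measured so far; the only other compound, compound 1, stands a modest distance away, as the step of a 2.5-fold lower number from compound 1 to compound 2 (0.40 log units; beyond the scatter) shows, with 1-cyclopropylethyl in place of 1-cyclopropyl-3-methoxypropyl on the aromatic nitrogen.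

Compound 3 `CCc1nc2c(-c3ccc(Cl)cc3Cl)ccnc2n1C(CC)CC` has not yet been measured. It differs from compound 2 in the same place: pentan-3-yl in place of 1-cyclopropylethyl on an aromatic nitrogen. For the measured compounds named here, only one measured step bears on this change, that from compound 1 to compound 2, and it was modest. That step traded a larger, ether-bearing chain for a smaller one; the present change keeps the size of the group the same and only swaps a ringed group for an open chain, so the expectation is a step of a 1.5-fold higher number from compound 2 to compound 3 (0.18 log units; within the scatter) that stays within the scatter, with no clear direction. Compound 3 is therefore estimated at 0.9 nM in this assay, within a range from 0.3 nM to 3 nM.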

Compound 3, inhibition constant: 1 nM
Estimate against measurement, compound 3: 1.1-fold (0.05 log units) below; the measured number falls inside the stated range.
By their numbers in this assay, from the lowest: compounds 2, 3 and 1 (each within the scatter of the next, the first and the last beyond it).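

Putting pentan-3-yl in place of 1-cyclopropylethyl on the aromatic nitrogen gives a 1.7-fold higher number from compound 2 to compound 3 (0.22 log units; within the scatter) in this assay so, with the heavy-atom count unchanged, removing the three-membered ring and the defined stereocentre produces no step beyond the scatter at this position. The comparison with the longer, ether-bearing group gives a 1.5-fold lower number from compound 1 to compound 3 (0.18 log units; within the scatter) and so compound 3 cannot be ordered against either of the other two compounds, even though the step between those two lies beyond the scatter. Nothing measured here explains why these groups give such similar numbers on this nitrogen.

The compounds shown leave open whether the numbers would stay this close with a longer chain such as heptan-4-yl, or with a chain ending in an amine or a carboxylic acid. They also leave open how the mirror-image form of the 1-cyclopropylethyl group would compare with the form carried by compound 2, and whether a cyclopentyl ring, which ties the two arms of pentan-3-yl together, would fit the same picture.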